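The compounds below may be only part of what the source reports. "The series", "measured", "known", "first", "only" and "open" are said of these compounds alone.

Three compounds share one core and differ only in the aryl group on an amide-type nitrogen in a ring. Compound 1 `COc1ccc(OC)c(N2C(=O)CSC2c2cccc(C(=O)NCCCCc3ccccc3)c2)c1` gives 92% in a functional assay on MG-63 cells (Homo sapiens) for inhibition, read by CCK-8 assay, with a stated time of 72 h, tested at 1 uM; a lower number here means less inhibition, a higher number more inhibition at the concentration tested (going by the name of the read-out). Compound 2 `CC(F)(F)c1cccc(N2C(=O)CSC2c2cccc(C(=O)NCCCCc3ccccc3)c2)c1` gives 92% in this assay, and compound 3 `COc1ccc(F)cc1N1C(=O)CSC1c1cccc(C(=O)NCCCCc2ccccc2)c1` gives 86% in this assay. Compound 3 has the lowest of the three numbers, yet both gaps, a number 6 percentage points lower from compound 1 to compound 3 (within the scatter) and a number 6 percentage points lower from compound 2 to compound 3 (within the scatter), lie within the scatter, so the three cannot really be told apart. Compound 4 `O=C(NCCCCc1ccccc1)c1cccc(C2SCC(=O)N2c2ccccc2F)c1` has not yet been measured; it differs from compound 3 by 2-fluorophenyl in place of 5-fluoro-2-methoxyphenyl on an amide-type nitrogen in a ring. Within the data shown here, the steps that bear on this are the earlier exchanges of groups on the same nitrogen: no change at the digits printed from compound 1 to compound 2 (within the scatter), a number 6 percentage points lower from compound 1 to compound 3 (within the scatter) and a number 6 percentage points lower from compound 2 to compound 3 (within the scatter), none of them beyond the scatter. Every change of this aryl group so far left the read-out essentially where it was, so the expected step for compound 4 is a number 1 percentage points lower from compound 3 to compound 4 (within the scatter), meaning no change beyond the scatter. Compound 4 is therefore estimated at 85%, within a range from 70% to 95%.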

Compound 4, a percentage reported as inhibition, at one concentration (the size of the read-out at that concentration, not a potency): 92%
Compound 4: the middle estimate sits 7 percentage points below what was measured; low and high end bracket the measured number.
By their numbers in this assay, from the lowest: compounds 3, 1, 2 and 4 (each within the scatter of the next).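

This position on the ring nitrogen also accepts a simpler aryl group: in this assay, 2-fluorophenyl, with fewer heavy atoms and no hydrogen-bond acceptor, gives a number 6 percentage points higher from compound 3 to compound 4 (within the scatter). Compared with the other two aryl groups, the result is the same, with no change at the digits printed from compound 2 to compound 4 (within the scatter) and no change at the digits printed from compound 1 to compound 4 (within the scatter), so neither the methoxy groups nor the difluoroethyl group is needed to keep the read-out at this concentration. Nothing available explains why these exchanges make so little difference.

As far as these compounds go, all four compounds carry a substituted phenyl ring on this nitrogen, so what a cyclohexyl ring, a pyridine ring or a plain methyl group would do stays open. Since this assay uses a single concentration, any differences in potency among the four also remain hidden.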